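Swapping the aryl group on the carbamate nitrogen

This account rests on a few compounds, and the source may have more. Where it says the series, first, only, none or still open, it means among the compounds named here.

Of the compounds shown here, three sharing one core have been tested in a functional assay on PANC-1 cells (Homo sapiens) for inhibition, read by MTT assay, with a stated time of 24 h, tested at 10 uM; on this read-out lower numbers stand for less inhibition and higher numbers for more inhibition at the one concentration tested (going by the name of the read-out). Compound 1 `CC(C)=CCC/C(C)=C/CC1Cc2c(OCc3ccccc3)cc(=O)n(CCCO)c2CC1(C)C` gives 1.5%, compound 2 `CC(C)=CCC/C(C)=C/CC1Cc2c(OCCCNC(=O)c3ccco3)cc(=O)n(CCCO)c2CC1(C)C` gives 2.8%, and compound 3 `COc1ccc(NC(=O)Oc2cc(=O)n(CCCO)c3c2CC(C/C=C(\C)CCC=C(C)C)C(C)(C)C3)cc1` gives 0%. All three numbers sit close together near zero: the step of a number 1.5 percentage points lower from compound 1 to compound 3 (within the scatter) and the step of a number 2.8 percentage points lower from compound 2 to compound 3 (within the scatter) both lie within the scatter, so compound 3 cannot be told apart from the other two in this assay.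

Compound 4 `CC(C)=CCC/C(C)=C/CC1Cc2c(OC(=O)Nc3cccc(F)c3)cc(=O)n(CCCO)c2CC1(C)C` differs from compound 3 in one place: 3-fluorophenyl in place of 4-methoxyphenyl on an amide-type nitrogen. For the measured compounds named here, none of the measured steps touches this position; the steps of a number 1.3 percentage points higher from compound 1 to compound 2 (within the scatter) and a number 1.5 percentage points lower from compound 1 to compound 3 (within the scatter) concern the group on the ring oxygen, not the aryl group on the amide-type nitrogen. Going by the values given here, there is therefore no measured precedent for this change, and since every measured value here is near zero, no step beyond the scatter is expected. Compound 4 is estimated at 2%, with a range from -5% to 10%, which amounts to an expected step of a number 2 percentage points higher from compound 3 to compound 4 (within the scatter).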

Compound 4, a percentage reported as inhibition, at one concentration (the size of the read-out at that concentration, not a potency): 0%
The estimate for compound 4 lay 2 percentage points above the measured number, within the range that was stated.
By their numbers in this assay, from the lowest: compounds 3, 4, 1 and 2 (each within the scatter of the next).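

In this assay the step of no change at the digits printed from compound 3 to compound 4 (within the scatter) is the only one measured at the amide-type nitrogen, and it shows that exchanging 4-methoxyphenyl for 3-fluorophenyl there gives a result that cannot be told apart from that of compound 3. The steps of a number 2.8 percentage points lower from compound 2 to compound 4 (within the scatter) and a number 1.5 percentage points lower from compound 1 to compound 4 (within the scatter) show that compound 4, with its (3-fluorophenyl)carbamoyl group on the oxygen, also cannot be told apart from the compounds carrying other groups at that oxygen. No evidence is at hand that would explain these results.

From the compounds shown here alone, whether an aryl ring bearing an amine or a carboxylic acid would give a different reading on this nitrogen remains open. So does the effect of replacing the aryl group with a longer alkyl chain.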